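Swapping the Acid Chain for a Hydroxyethoxy Tail

The source may report more compounds than this note shows. Statements on the series, on what has been measured and on what is new or still open speak of the compounds shown alone.

Among the measured compounds shown here, compound 2 `CC(C)c1onc(-c2c(Cl)cccc2Cl)c1COc1ccc(N(C)Cc2ccc(CCC(=O)O)cc2)c(C(F)(F)F)n1` holds the only number so far in a functional assay on HEK293 cells for agonist activity at Bile acid receptor (Homo sapiens), read by a luciferase reporter (a lower number here means that less compound is needed, a higher number that more compound is needed for the effect), where compound 2 gives 16 nM. Compound 1 `Cc1cc(C(F)(F)F)cc(OCc2c(-c3c(Cl)cccc3Cl)noc2C(C)C)n1` is recorded in this assay as "not active" (no number reported), with no figure behind it. Compound 3 `CC(C)c1onc(-c2c(Cl)cccc2Cl)c1COc1ccc(N(C)Cc2ccc(OCCO)cc2)c(C(F)(F)F)n1` differs from compound 2 in a single place: 2-hydroxyethoxy in place of 2-carboxyethyl on an aromatic carbon. For the measured compounds named here, no measured pair shows this exact change, so any step here is an expectation only: the step of a 4.4-fold higher number from compound 2 to compound 3 (0.64 log units; beyond the scatter) is expected to be a loss of potency somewhat beyond the usual scatter. Compound 3 is therefore estimated at 70 nM, likely within 15 nM to 400 nM.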

Compound 3, half-maximal effective concentration: 155 nM
Beside the measured number, compound 3's estimate is 2.2-fold (0.35 log units) below it; the range from low to high includes it.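

Putting 2-hydroxyethoxy in place of 2-carboxyethyl on this aromatic carbon gives a 9.7-fold higher number from compound 2 to compound 3 (0.99 log units; beyond the scatter) in this assay and so costs potency. Even so, compound 3 still gives a measured number, so a carboxylic acid at this position is not needed for a response in this assay, though the 2-carboxyethyl group gives the lower number. Nothing shown here explains the loss. Still open, from the compounds shown here alone, is whether an amine, an amide or a longer chain ending in a hydroxyl at this position would recover the lost potency.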